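Des-chloro analogue in the aryl-pyrazole diazepane series

A few compounds are considered here, and "the series" means these few. Any claim that something is new, unique, unknown or untested is made for them only; others in the source may bear on it.

Measured so far:
compound 1 `Cc1cccc(-c2n[nH]cc2N2CCCNCC2)c1` — > 10000 nM
compound 2 `Clc1ccc(-c2n[nH]cc2N2CCCNCC2)cc1` — > 10000 nM

In an assay on isolated protein for binding affinity to 5-hydroxytryptamine receptor 1E (Homo sapiens) (a lower number here means a stronger inhibitor, a higher number a weaker inhibitor), compound 1 gives only a limit, > 10000 nM. In this assay compound 2 likewise gives only a limit, > 10000 nM. Within the data shown here, compound 2 therefore stands at the limit of > 10000 nM in this assay, at which 2 of the 2 values shown sit, so no measured step is available for the series.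

Compound 3 `c1ccc(-c2n[nH]cc2N2CCCNCC2)cc1` carries hydrogen in place of chloro on an aromatic carbon, that is, hydrogen in place of chloro on an aromatic carbon. Among the measured compounds shown here, with no measured step to draw on, no shift beyond the scatter is expected in this assay, and the estimated step that the limit leaves unreadable from compound 2 to compound 3 is flat. Compound 3 is expected to give 15000 nM, in the range 5000 nM to 50000 nM, most likely again reported only as a limit.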

Compound 3, inhibition constant: > 10000 nM
Compound 3 ended at the assay's limit; the forecaster's own chance of this, stated with the estimate: 80%; the middle value is on the limit's open side.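

Among these compounds, compound 3, like compound 1 and compound 2, gives only a limit in this assay, so no step among them can be read. The compounds shown leave open whether hydrogen, chloro or methyl on the aromatic carbon makes any difference.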